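The compounds below may be only part of what the source reports. "The series", "measured", "known", "first", "only" and "open" are said of these compounds alone.

Measured compounds:
compound 1, `CC(C)Sc1nnc(-c2c(CN3CCCCC3C)c3ccccc3n2C)n1-c1ccccc1`, gives 5.95 in a physicochemical assay for lipophilicity; a lower number here means a more polar compound, a higher number a more lipophilic compound
compound 2, `CC1CCCN(Cc2c(-c3nnc(SC(C)C)n3-c3ccccc3)n(C)c3ccccc23)C1`, gives 6.03 in this assay

Among the compounds with values here, compound 1 stands at the lower of the two numbers in this assay, with compound 2 as its only neighbour; the step of a number 0.08 log units higher from compound 1 to compound 2 (within the scatter) lies within the scatter, so the two compounds cannot be told apart on this read-out. Compound 3, `CC(C)Sc1nnc(-c2c(CNc3cnccn3)c3ccccc3n2C)n1-c1ccccc1`, has not yet been measured. It differs from compound 1 in one place: (pyrazin-2-yl)amino in place of 2-methylpiperidin-1-yl on a saturated chain carbon bound to an aromatic carbon. Within the data shown here, the only measured step, a number 0.08 log units higher from compound 1 to compound 2 (within the scatter), concerns a different kind of change and does not bear on this one, so the expectation rests on the counted difference alone and carries a wide range. Compound 3 is expected to come out markedly more polar than compound 1, with an estimated step of a number 1.55 log units lower from compound 1 to compound 3 (beyond the scatter). Compound 3 is estimated at 4.4, between 3.7 and 5.1.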

Compound 3, partition coefficient: 4.22
The estimate for compound 3 lay 0.18 log units above the measured number, within the range that was stated.
By their numbers in this assay, from the lowest: compound 3; then compounds 1 and 2 (each within the scatter of the next).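

The position on the saturated chain carbon, which gave no readable change when only the methyl moved around the piperidine, turns out to respond strongly in this assay when the whole group is exchanged. Replacing either methylpiperidine with (pyrazin-2-yl)amino lowers the number by a similar large amount (a number 1.73 log units lower from compound 1 to compound 3 (beyond the scatter); a number 1.81 log units lower from compound 2 to compound 3 (beyond the scatter)), even though the heavy-atom count of the group stays the same and only its atom types, ring type and hydrogen-bond counts differ. No supporting measurement is available to explain this drop.

The exchange alters several features at once, so these compounds leave open which of them accounts for the step. A phenylamino group, which keeps the amino link but has no ring nitrogen, or a morpholin-4-yl group, which keeps a saturated ring, would help separate those features.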